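From 5-methoxypyrazin-2-yl to benzyloxy on a shared core

The compounds below may be only part of what the source reports. "The series", "measured", "known", "first", "only" and "open" are said of these compounds alone.

Of the compounds shown here, three with one shared core have been measured in an ADME assay on the whole organism (Rattus norvegicus), at a dose of 2 mg/kg by the oral route; a higher number here means more compound in the circulation at the dose given, a lower number less compound in the circulation. Compound 1 (`COc1cc(OCc2cccc(-c3ccc(C(F)(F)F)cn3)c2)c2cc(-c3cn4nc(OC)sc4n3)oc2c1`), carrying 5-(trifluoromethyl)pyridin-2-yl, gives 459 ng.h/mL. Compound 2 (`COc1cc(OCc2cccc(-c3cnc(OC)nc3)c2)c2cc(-c3cn4nc(OC)sc4n3)oc2c1`), carrying 2-methoxypyrimidin-5-yl, gives 1030 ng.h/mL. Compound 3 (`COc1cc(OCc2cccc(-c3cnc(OC)cn3)c2)c2cc(-c3cn4nc(OC)sc4n3)oc2c1`), carrying 5-methoxypyrazin-2-yl, gives 722 ng.h/mL, which lies within the scatter of both other values. This shows in two steps: a 1.6-fold higher number from compound 1 to compound 3 (0.20 log units; within the scatter) and a 1.4-fold lower number from compound 2 to compound 3 (0.15 log units; within the scatter). Among the compounds with values here, only one step goes beyond the scatter, and it is modest: a 2.2-fold higher number from compound 1 to compound 2 (0.35 log units; beyond the scatter).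

Compound 4 (`COc1cc(OCc2cccc(OCc3ccccc3)c2)c2cc(-c3cn4nc(OC)sc4n3)oc2c1`) has benzyloxy in place of 5-methoxypyrazin-2-yl on an aromatic carbon. Within the data shown here, none of the measured steps brings in benzyloxy, or any group with a six-membered aromatic ring of carbon only, so they offer only indirect guidance. They do show that swapping one group for another here has so far moved the number little, so a large jump is not expected. The new ring type still leaves real uncertainty, and a slight drop seems a little more likely than a rise. The estimated step is a 1.6-fold lower number from compound 3 to compound 4 (0.21 log units; within the scatter), which would remain a small one. For compound 4 the estimated value is 450 ng.h/mL, with an expected range of 150 ng.h/mL to 1100 ng.h/mL.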

Compound 4, area under the concentration-time curve: 339 ng.h/mL
Estimate against measurement, compound 4: 1.3-fold (0.12 log units) above, within the range that was stated.
By their numbers in this assay, from the lowest: compounds 4, 1, 3 and 2 (each within the scatter of the next, the first and the last beyond it).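

Benzyloxy is the first group at this position with a six-membered aromatic ring of carbon only, and in this assay it separates from both methoxy-bearing rings: 5-methoxypyrazin-2-yl (a 2.1-fold lower number from compound 3 to compound 4 (0.33 log units; beyond the scatter)) and 2-methoxypyrimidin-5-yl (a 3.0-fold lower number from compound 2 to compound 4 (0.48 log units; beyond the scatter)). The second of these is the widest step yet seen at this position, though still a modest one. Compound 1 goes against any simple rule that hetero atoms in this ring raise the number, since 5-(trifluoromethyl)pyridin-2-yl, which has one, does not separate from benzyloxy (a 1.4-fold lower number from compound 1 to compound 4 (0.13 log units; within the scatter)).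

Benzyloxy also differs from the other groups in carrying an oxygen and a carbon chain link before its ring, so the shared core with a plain phenyl, or with a pyridine on the same benzyloxy-type link, would be needed to tell the ring change from the link change. As far as these compounds go, how an amine or a carboxylic acid at this place would compare also stays open. Nothing shown here gives a measured reason for these differences.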